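This account rests on a few compounds, and the source may have more. Where it says the series, first, only, none or still open, it means among the compounds named here.

The measured compounds are these:

compound 1, `O=C(COCc1ccccc1)N1CCN(c2ccccc2)CC1`, 7100 nM
compound 2, `O=C(COCc1ccccc1)N1CCN(c2cccc(Cl)c2)CC1`, 6700 nM
compound 3, `O=C(COCc1ccccc1)N1CCN(c2ccc(F)cc2F)CC1`, 300 nM

All three share one core and differ only in the ring on the amine nitrogen. In a functional assay on HEK293 cells for positive allosteric modulation of metabotropic glutamate receptor 5 (Homo sapiens), read by FLIPR and calcium flux (on this read-out higher numbers stand for an effect only at larger amounts of compound and lower numbers for an effect already at smaller amounts), compound 3 gives the lowest number of the three: the steps of a 24-fold lower number from compound 1 to compound 3 (1.37 log units; beyond the scatter) and a 22-fold lower number from compound 2 to compound 3 (1.35 log units; beyond the scatter) are both large and well beyond the scatter, so compound 3 is the most potent of the measured set. Compound 4, `O=C(COCc1ccccc1)N1CCN(c2ccc(F)cc2Cl)CC1`, has not yet been measured. It differs from compound 3 by a single exchange, (chloro in place of fluoro on an aromatic carbon), or in other words a 2-chloro-4-fluorophenyl ring in place of the 2,4-difluorophenyl ring.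

Among the measured compounds shown here, only one measured step involves a chloro group entering the ring, a 1.1-fold lower number from compound 1 to compound 2 (0.03 log units; within the scatter), and that step lies within the scatter; it is, however, a chloro replacing hydrogen at a different place on the ring, not a chloro replacing fluoro. For the measured compounds named here, no measured pair swaps fluoro for chloro directly, so the bearing of the data on this change is loose. Compound 4 is therefore expected to give a step of about a 1.1-fold lower number from compound 3 to compound 4 (0.03 log units; within the scatter), that is no clear change beyond the scatter in either direction. The estimate for compound 4 in this assay is 280 nM, with a range from 80 nM to 1000 nM.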

Compound 4, half-maximal effective concentration: 270 nM
Beside the measured number, compound 4's estimate is 1.0-fold (0.02 log units) above it; measured number inside the range.
By their numbers in this assay, from the lowest: compounds 4 and 3 (each within the scatter of the next); then compounds 2 and 1 (each within the scatter of the next).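

In this assay, among the compounds shown here, the step of a 1.1-fold lower number from compound 3 to compound 4 (0.05 log units; within the scatter) gives the first direct reading of chloro in place of fluoro on this aromatic carbon, ortho to a large group, and the exchange leaves no difference that can be told from the scatter. The low number is therefore not tied to the 2,4-difluorophenyl ring alone, since the 2-chloro-4-fluorophenyl ring also stands far from the other two rings, with a 25-fold lower number from compound 2 to compound 4 (1.39 log units; beyond the scatter) and a 26-fold lower number from compound 1 to compound 4 (1.42 log units; beyond the scatter) both large. Chloro alone does not bring this about, as the 3-chlorophenyl ring of compound 2 reads alongside the unsubstituted phenyl ring of compound 1 at the high end of the set.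

No measurement at hand accounts for these results. The compounds shown leave open how much of the effect rests on the group at this position and how much on the fluoro group of the 2-chloro-4-fluorophenyl ring, and whether bromo, methyl or methoxy at this position would read as chloro and fluoro do here.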